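This account rests on a few compounds, and the source may have more. Where it says the series, first, only, none or still open, it means among the compounds named here.

Of the compounds shown here, three sharing one core have been measured in a physicochemical assay for solubility, in phosphate buffer, at pH 7.4; on this read-out higher numbers stand for higher solubility and lower numbers for lower solubility. Compound 1 `N/C(=N/O)c1ccc2[nH]c(-c3cccc(-c4ccccc4O)c3O)cc2c1` gives 380000 nM. Compound 2 `C=CCO/N=C(/N)c1ccc2[nH]c(-c3cccc(-c4ccccc4O)c3O)cc2c1` gives 24000 nM, and compound 3 `CC(C)ONC(=N)c1ccc2[nH]c(-c3cccc(-c4ccccc4O)c3O)cc2c1` gives 25000 nM. Compound 3 therefore holds the second highest of the three numbers: its gap to compound 2 is described by a 1.0-fold higher number from compound 2 to compound 3 (0.02 log units; within the scatter), so the two cannot be told apart, while the drop from the unsubstituted parent is described by a 15-fold lower number from compound 1 to compound 3 (1.18 log units; beyond the scatter), a step as large as a 16-fold lower number from compound 1 to compound 2 (1.20 log units; beyond the scatter).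

Compound 4 `CC(=O)OC(C)OC(=O)NC(=N)c1ccc2[nH]c(-c3cccc(-c4ccccc4O)c3O)cc2c1` differs from compound 3 by (1-acetoxyethoxy)carbonyl in place of isopropoxy on an amine nitrogen. For the measured compounds named here, the steps that bear on this change are the two large drops from compound 1 on adding a substituent at this end of the molecule, and the step from compound 2 to compound 3, which shows that exchanging one such substituent for another of similar size changes nothing beyond the scatter. A larger group now enters, so a modest further lowering of this assay is expected, giving a 2.1-fold lower number from compound 3 to compound 4 (0.32 log units; beyond the scatter). Compound 4 is thus estimated at 12000 nM, with a range from 4000 nM to 40000 nM.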

Compound 4, solubility: < 10000 nM
Compound 4: a limit, no number; the forecaster's own chance of this, stated with the estimate: 5%; middle value at least 1.2-fold (0.07 log units) from the limit.
By their numbers in this assay, from the lowest: compounds 2 and 3 (each within the scatter of the next); then compound 1. At a limit, below all of these: compound 4.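

In this assay compound 4 gives < 10000 nM, which is a limit of the assay and not a number. Read from that limit, the step is an at least 2.5-fold lower number from compound 3 to compound 4 (0.39 log units; beyond the scatter), so (1-acetoxyethoxy)carbonyl on this amine nitrogen does what the earlier exchange of similar-sized groups did not, since that exchange, a 1.0-fold higher number from compound 2 to compound 3 (0.02 log units; within the scatter), left two compounds that cannot be told apart. How far the number really falls stays unknown, as the reading stops at the end of the assay's range: the limit of < 10000 nM in this assay, at which 1 of the 4 values shown sits.

The compounds shown leave open whether the size of the entering group or its carbonyl and acetoxy parts accounts for the step. A plain methoxycarbonyl, or a longer chain ending in an amine, on the same amine nitrogen would help separate these two readings.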